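A few compounds are considered here, and "the series" means these few. Any claim that something is new, unique, unknown or untested is made for them only; others in the source may bear on it.

Measured so far:
Compound 1 `N#CC1=C(N)Oc2c(c3nc4ccccc4nc3c3ccccc23)C12C(=O)N(Cc1cnnn1-c1ccccc1Br)c1ccccc12`. In an ADME assay on HUVEC cells (Homo sapiens) for antiproliferative activity, read by MTT assay, with a stated time of 48 h (on this read-out lower numbers stand for stronger inhibition and higher numbers for weaker inhibition), compound 1 gives > 50000 nM; this is a limit of the assay, not a number.
Compound 2 `COc1ccc(-n2nncc2CN2C(=O)C3(C(C#N)=C(N)Oc4c3c3nc5ccccc5nc3c3ccccc43)c3ccccc32)cc1`. In this assay compound 2 gives > 50000 nM, again a limit.
Compound 3 `CCc1ccccc1-n1nncc1CN1C(=O)C2(C(C#N)=C(N)Oc3c(N)cc4nc5ccccc5nc4c32)c2ccccc21`. In this assay compound 3 gives > 50000 nM, also a limit.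

All three measured values sit at the same point, (the limit of > 50000 nM in this assay, at which 3 of the 3 values shown sit), so compound 3 stands nowhere distinct: its value is a limit, like the two others, and no order among the three can be read. Going by the values given here, the single pair that differs in only one place, a step that the two limits leave unreadable from compound 1 to compound 2, shows this directly: with both ends at the limit, the size of that step cannot be read.

Compound 4 `N#CC1=C(N)Oc2c(N)cc3nc4ccccc4nc3c2C12C(=O)N(Cc1cnnn1-c1ccc(Cl)cc1Cl)c1ccccc12` differs from compound 3 in one place: 2,4-dichlorophenyl in place of 2-ethylphenyl on an aromatic nitrogen. Among the compounds with values here, no measured step bears on this change, and the one step among the measured compounds is itself unreadable. The expectation therefore rests on where compound 3 stands, which is at the limit. The expected step is a step that the limit leaves unreadable from compound 3 to compound 4, that is, no change that can be resolved. Compound 4 is expected to give 60000 nM in this assay, within 20000 nM to 200000 nM, most likely reported again only as a limit.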

Compound 4, half-maximal inhibitory concentration: > 50000 nM
Compound 4 was reported as a limit; the forecaster's own chance of this, stated with the estimate: 85%; the middle value does not contradict the limit.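

In this assay compound 4 gives > 50000 nM, which is a limit and not a number. Compound 3 also stands at a limit, so the size of the step between compound 3 and compound 4 cannot be read: the limit of > 50000 nM in this assay, at which 4 of the 4 values shown sit. The compounds shown leave open whether changing the group on the aromatic nitrogen alters the activity at all.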